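The source may hold more compounds than are shown below. What is called first, only, known or untested is meant among the compounds shown, and "the series" means these compounds.

Three compounds built on one shared core were tested in an assay on isolated protein for inhibition of Voltage-dependent L-type calcium channel subunit alpha-1C (Cavia porcellus); a lower number here means a stronger inhibitor, a higher number a weaker inhibitor. Compound 1 `CCOC(=O)C1=C(C)NC(C)=C(C(=O)OCC)C1c1[nH]cnc1Cl` gives 437 nM in this assay, the second highest of the three numbers. Compound 2 `CC1=C(C(=O)OC(C)(C)C)C(c2[nH]cnc2Cl)C(C(=O)OC(C)(C)C)=C(C)N1` gives 4070 nM in this assay, a higher number than compound 1 by more than the usual scatter, while compound 3 `CC1=C(C(=O)OCCCc2ccccc2)C(c2nc[nH]c2Cl)C(C(=O)OCCCc2ccccc2)=C(C)N1` gives 1.74 nM in this assay, a far lower number than compound 1. Compound 1, with its ethyl esters, thus sits between the other two.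

Compound 4 `CCOC(=O)C1=C(C)NC(C)=C(C(=O)OCc2ccccc2)C1c1[nH]cnc1Cl` has not yet been measured. It differs from compound 1 in one place: phenyl in place of methyl on a saturated chain carbon bound to an oxygen next to a carbonyl group. Going by the values given here, no measured pair shows exactly this change. Among the compounds with values here, still, compound 3, which also carries phenyl groups, shows 1.74 nM, so a lower number is expected for compound 4 than for compound 1, even though only one ester side changes here. The step from compound 1 to compound 4 is expected to be a 7.3-fold lower number from compound 1 to compound 4 (0.86 log units; beyond the scatter). Compound 4 is estimated at 60 nM in this assay, with a range from 12 nM to 300 nM.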

Compound 4, half-maximal inhibitory concentration: 91.2 nM
Compound 4: the middle estimate sits 1.5-fold (0.18 log units) below what was measured, within the range that was stated.
By their numbers in this assay, from the lowest: compound 3; then compound 4; then compound 1; then compound 2.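

In this assay, going by these compounds alone, the change from ethoxy to benzyloxy gives a 4.8-fold lower number from compound 1 to compound 4 (0.68 log units; beyond the scatter), and this is the first pair of compounds here that differ in only one place. It shows that this position accepts a phenyl in place of the methyl, and that altering a single ester while the other stays ethyl is enough to move the number beyond the usual scatter. Nothing measured here explains this step.

Still open, on these data alone, is whether the aromatic ring itself matters, which a cyclohexyl group or a plain longer chain in place of the phenyl could test, and whether a carboxylic acid or an amine at the end of the chain would be accepted. Also open, as far as these compounds go, is what a second benzyl ester, replacing the remaining ethyl ester of compound 4, would give.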